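Notes on the step to compound 4

The source may report more compounds than this note shows. Statements on the series, on what has been measured and on what is new or still open speak of the compounds shown alone.

Values in a functional assay on BGC-823 cells (Homo sapiens) for antiproliferative activity, read by MTT assay, with a stated time of 24 h; on this read-out lower numbers stand for stronger inhibition and higher numbers for weaker inhibition:
- compound 1 (`O=[N+]([O-])c1cccc(CSc2nnc(-c3ccc4c(c3)OCCO4)n2-c2ccccc2)c1`): 30100 nM
- compound 2 (`COc1cccc(CSc2nnc(-c3ccc4c(c3)OCCO4)n2-c2ccccc2)c1`): > 100000 nM (a limit)
- compound 3 (`Cc1ccccc1CSc1nnc(-c2ccc3c(c2)OCCO3)n1-c1ccccc1`): > 100000 nM (a limit)

In this assay compound 3 stands only at a limit (> 100000 nM) and gives no number. Compound 4 (`Fc1ccc(CSc2nnc(-c3ccc4c(c3)OCCO4)n2-c2ccccc2)cc1`) carries 4-fluorophenyl in place of 2-methylphenyl on a saturated chain carbon bound to a sulfur.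

Going by the values given here, two measured steps bear on this change, both starting from compound 1 and both beyond the scatter: an at least 3.3-fold higher number from compound 1 to compound 2 (0.52 log units; beyond the scatter) and an at least 3.3-fold higher number from compound 1 to compound 3 (0.52 log units; beyond the scatter). The remaining one is a step that the two limits leave unreadable from compound 2 to compound 3 and adds no size. Compound 4 has no nitro group, so it is expected to resemble compound 3 rather than compound 1, given an at least 3.3-fold higher number from compound 1 to compound 3 (0.52 log units; beyond the scatter).

The expected change is small, towards a slightly lower number at most: an at least 1.4-fold lower number from compound 3 to compound 4 (0.15 log units; that floor lies within the scatter). For compound 4 the estimate is 70000 nM (expected range 25000 nM to 150000 nM), and a reading that is again only a limit is quite possible.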

Compound 4, half-maximal inhibitory concentration: > 100000 nM
Compound 4: only a limit was reported; the forecaster's own chance of this, stated with the estimate: 55%; at least 1.4-fold (0.15 log units) between middle value and limit.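

In this assay compound 4 gives > 100000 nM, which is a limit and not a number. Going by these compounds alone, the one readable step is an at least 3.3-fold higher number from compound 1 to compound 4 (0.52 log units; beyond the scatter), so 4-fluorophenyl now joins 3-methoxyphenyl and 2-methylphenyl among the replacements for 3-nitrophenyl on this saturated chain carbon bound to a sulfur that give no number, and compound 1 remains the only one of the four with a measured value. The steps among compounds 2, 3 and 4 cannot be read, and the series now gathers at a single limit: the limit of > 100000 nM in this assay, at which 3 of the 4 values shown sit.

Going by these compounds, how compounds 2, 3 and 4 differ from one another stays open. Also open, on these data alone, is whether a nitrile or a carboxylic acid in place of the nitro group would give a measurable number, as the nitro group does in compound 1.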